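Chloro for methyl on the aryl ring: two cores compared

The source may hold more compounds than are shown below. What is called first, only, known or untested is meant among the compounds shown, and "the series" means these compounds.

Measured so far:
- compound 1 `Cc1cc(C(F)(F)F)ccc1-c1cc2cnn([C@@H](CC(C)C)c3ccc(C(=O)NCCC(=O)O)cc3)c2cc1C`: 81%
- compound 2 `Cc1cc(C(F)(F)F)ccc1-c1ccc2nn([C@@H](CC(C)C)c3ccc(C(=O)NCCC(=O)O)cc3)cc2c1C`: 110%
- compound 3 `Cc1cc2c(cnn2[C@@H](CC(C)C)c2ccc(C(=O)NCCC(=O)O)cc2)cc1-c1ccc(C(F)(F)F)cc1Cl`: 62%

The series is followed in an ADME assay on microsomes from liver (Homo sapiens) for metabolic stability, with a stated time of 10 min, tested at 1 uM; on this read-out lower numbers stand for a less stable compound and higher numbers for a more stable compound. Compound 1 and compound 2 are built from the same atoms joined differently; the difference between the two cores is not broken down here. Compound 2 stands highest of the three, with compound 1 nearest and compound 3 furthest, both gaps beyond the scatter.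

Between compound 1 and compound 3 the change is chloro in place of methyl on an aromatic carbon, and the step is a number 19 percentage points lower from compound 1 to compound 3 (beyond the scatter). The change from compound 2 to compound 4 `Cc1c(-c2ccc(C(F)(F)F)cc2Cl)ccc2nn([C@@H](CC(C)C)c3ccc(C(=O)NCCC(=O)O)cc3)cc12` is chloro in place of methyl on an aromatic carbon, the same change at the same place, now on the core of compound 2.

Within the data shown here, for compound 4 a step of about a number 19 percentage points lower from compound 2 to compound 4 (beyond the scatter) in this assay is expected, set beside the earlier one, resting on the single measured pair compound 1 to compound 3 and on compound 2 giving 110%. As far as these compounds go, whether the core of compound 2 carries the change alike is untested. Compound 4 is therefore estimated at 91%, between 72% and 108%.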

Compound 4, percent of the compound remaining: 118%
Compound 4: middle estimate off by 27 percentage points, on the low side; the measured number lies above the stated range.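

On the core of compound 2, going from 2-methyl-4-(trifluoromethyl)phenyl to 2-chloro-4-(trifluoromethyl)phenyl gives a step in this assay of a number 8 percentage points higher from compound 2 to compound 4 (within the scatter), so no shift can be read on this core. Chloro in place of methyl therefore does not carry over as a fixed step between these two cores: the same change on two cores in this assay, a number 19 percentage points lower (beyond the scatter) from compound 1 to compound 3 and a number 8 percentage points higher (within the scatter) from compound 2 to compound 4, 27 percentage points apart, beyond the scatter of two such steps

This rests on a single pair for each core, so it shows that the outcome of the change differs between these two cores, but not which feature of the cores lies behind the difference or what a third core would give.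

The compounds shown leave open whether another group in place of the methyl, such as a fluoro or a nitrile, would also give different steps on the two cores. They also leave open whether a step measured on one core can be carried to the other for any change at this place.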